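The compounds below may be only part of what the source reports. "The series", "measured", "known", "first", "only" and "open" are said of these compounds alone.

Measured so far in a functional assay on CCRF-CEM cells (Homo sapiens) for inhibition, read by MTT assay, with a stated time of 72 h; a lower number here means a stronger inhibitor, a higher number a weaker inhibitor:
Compound 1 `COc1cc(NC(C)CCCNC(=O)Nc2cccc(F)c2)c2ncccc2c1` gives 21000 nM.
Compound 2 `COc1cc(NC(C)CCCNC(=O)NNC(=O)Nc2ccc(F)cc2)c2ncccc2c1` gives 118000 nM.

Within the data shown here, compound 2 carries the highest of the two numbers; the only neighbour is compound 1, and the step of a 5.6-fold higher number from compound 1 to compound 2 (0.75 log units; beyond the scatter) lies beyond the scatter. Compound 3 `COc1cc(NC(C)CCCNC(=O)NNC(=O)Nc2cccc(Cl)c2)c2ncccc2c1` differs from compound 2 by 3-chlorophenyl in place of 4-fluorophenyl on an amide-type nitrogen. Among the measured compounds shown here, no measured step isolates this exchange: the single step recorded changes the linker as well as the ring, so it does not bear on a halogen swap alone. Compound 3 is therefore expected near compound 2, with a step of a 1.2-fold lower number from compound 2 to compound 3 (0.07 log units; within the scatter) not beyond the scatter, and an estimate of 100000 nM, range 40000 nM to 300000 nM.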

Compound 3, half-maximal inhibitory concentration: 81000 nM
Compound 3: the middle estimate sits 1.2-fold (0.09 log units) above what was measured, and the stated range covers the measured number.
By their numbers in this assay, from the lowest: compound 1; then compounds 3 and 2 (each within the scatter of the next).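

In this assay, the exchange of 4-fluorophenyl for 3-chlorophenyl on the amide-type nitrogen gives (a 1.5-fold lower number from compound 2 to compound 3 (0.16 log units; within the scatter)), so these two rings are not separated at this position. Replacing 3-fluorophenyl with ((3-chlorophenyl)carbamoyl)amino gives (a 3.9-fold higher number from compound 1 to compound 3 (0.59 log units; beyond the scatter)), showing that the higher number seen with compound 2 also holds with a second ring. Nothing available explains either step.

Going by these compounds, the halogen and its ring position change together here, so their separate contributions remain open. Also open, on these data alone, is how a ring bearing an amine or a carboxylic acid would read at this position.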